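Carbamoyl in Place of Hydroxy: What to Expect of Compound 4

This account rests on a few compounds, and the source may have more. Where it says the series, first, only, none or still open, it means among the compounds named here.

Of the compounds shown here, three have so far been measured in a functional assay on the whole organism (Tail, strain ICR) with Mus musculus as the target, in the tail flick test, with a stated time of 60 min, at a dose of 25 umol/kg by the oral route; on this read-out lower numbers stand for a weaker effect and higher numbers for a stronger effect at the one dose given. Compound 1 `O=C(CN(c1nc(Cl)nc2[nH]cnc12)C1CC1)N[C@@H](CO)C(=O)O` gives 39.8% in this assay, compound 2 `NC(=O)C[C@H](NC(=O)CN(c1nc(Cl)nc2[nH]cnc12)C1CC1)C(=O)O` gives 43.1%, and compound 3 `O=C(CN(c1ncnc2c1ncn2C1CCCCO1)C1CC1)N[C@@H](CO)C(=O)OCc1ccccc1` gives 46.7%. Compound 3 carries the highest of the three numbers, but its gap to compound 2 and its gap to compound 1 both lie within the usual scatter of this kind of measurement, so the three values cannot be ranked with any confidence.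

Compound 2 differs from compound 1 in one place: carbamoyl in place of hydroxy on a saturated chain carbon, two bonds along the chain from an amide-type nitrogen and a carbonyl carbon. In this assay this change made a number 3.3 percentage points higher from compound 1 to compound 2 (within the scatter).

Compound 4 `NC(=O)C[C@H](NC(=O)CN(c1ncnc2c1ncn2C1CCCCO1)C1CC1)C(=O)OCc1ccccc1` is not yet measured in this assay. It differs from compound 3 by the same change, (carbamoyl in place of hydroxy on a saturated chain carbon, two bonds along the chain from an amide-type nitrogen and a carbonyl carbon), at the same place. The difference between the core of compound 1 and the core of compound 3 is not broken down here; the two cores are compared only through their measured numbers.

Among the compounds with values here, the single measured instance of this change left the read-out essentially where it was, so compound 4 is expected to land close to compound 3. In this assay, within the data shown here, the expected step is a number 3.3 percentage points higher from compound 3 to compound 4 (within the scatter), because the only measured instance of this change gave a number 3.3 percentage points higher from compound 1 to compound 2 (within the scatter). Compound 4 is accordingly estimated at 50%, with a likely range from 36% to 64%.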

Compound 4, a percentage reported as activity, at one dose (the size of the read-out at that dose, not a potency): 30.5%
Beside the measured number, compound 4's estimate is 19.5 percentage points above it, outside the stated range (below it).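

In this assay the replacement of hydroxy by carbamoyl gave a number 16.2 percentage points lower from compound 3 to compound 4 (beyond the scatter) and so did not behave on the core of compound 3 as it had on the core of compound 1, as the two steps set side by side make plain: the same change on two cores in this assay, a number 3.3 percentage points higher (within the scatter) from compound 1 to compound 2 and a number 16.2 percentage points lower (beyond the scatter) from compound 3 to compound 4, 19.5 percentage points apart, beyond the scatter of two such steps. Within the data shown here, in this small series, then, the step measured on one core could not be carried over to the other, either in size or in direction, and the single earlier instance was a poor guide to the second. The comparison does not show which part of the difference between the two cores accounts for the gap, it offers no rule for any further core, and, resting on a single dose and a single stated time, it says nothing about potency.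

The compounds shown leave open how the read-out would respond on either core to an amine at this same place, or to a longer chain ending in carbamoyl. They also leave open whether the hydroxy and carbamoyl pair would behave the same way on a core that differs from the core of compound 3 in only one part.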